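From cyclobutyl to cyclohexyl at the assay limit

The source may hold more compounds than are shown below. What is called first, only, known or untested is meant among the compounds shown, and "the series" means these compounds.

Of the compounds shown here, three sharing one core have been tested: compound 1 (`CCn1nc(C(=O)N[C@H]2COc3ccccc3N(C)C2=S)nc1Cc1ccccc1`), compound 2 (`CC(C)Cn1nc(C(=O)N[C@H]2COc3ccccc3N(C)C2=S)nc1Cc1ccccc1`) and compound 3 (`CN1C(=S)[C@@H](NC(=O)c2nc(Cc3ccccc3)n(C3CCC3)n2)COc2ccccc21`). In a toxicity assay on HT-29 cells (Homo sapiens) for cytotoxicity (on this read-out higher numbers stand for lower toxicity in this test and lower numbers for higher toxicity in this test), compound 1 gives > 100000 nM as a limit and not a number. Compound 2 gives > 100000 nM as a limit too. Compound 3 gives > 100000 nM as a limit as well. Compound 3 thus stands at the limit of > 100000 nM in this assay, at which 3 of the 3 values shown sit, and has no number of its own.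

Compound 4 (`CN1C(=S)[C@@H](NC(=O)c2nc(Cc3ccccc3)n(C3CCCCC3)n2)COc2ccccc21`) has not yet been measured and carries cyclohexyl in place of cyclobutyl on an aromatic nitrogen. The changes of this group already measured are a step that the two limits leave unreadable from compound 1 to compound 2 and a step that the two limits leave unreadable from compound 1 to compound 3 and a step that the two limits leave unreadable from compound 2 to compound 3 and none gives a size, so they offer no ground for expecting compound 4 to move away from the limit. The expected change is therefore a number no higher from compound 3 to compound 4 (the limit leaves the size open) in this assay with no direction and nothing beyond the scatter. For compound 4 the estimate is 100000 nM with an expected range from 40000 nM to 200000 nM and the assay may well report only a limit again.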

Compound 4, half-maximal cytotoxic concentration: > 100000 nM
Compound 4: no number, only a limit; the forecaster's own chance of this, stated with the estimate: 85%; the middle value lies on the limit itself.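

Among the compounds shown here, compound 4 also returns only a limit, so no step among compound 1, compound 2, compound 3 and compound 4 can be read: the limit of > 100000 nM in this assay, at which 4 of the 4 values shown sit. The compounds shown leave open whether any of these groups on the aromatic nitrogen changes the half-maximal cytotoxic concentration, and by how much.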